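Swapping a methyl for a phenyl on a selenium-containing core

The source may report more compounds than this note shows. Statements on the series, on what has been measured and on what is new or still open speak of the compounds shown alone.

Of the compounds shown here, three have been tested so far in a functional assay on DU-145 cells (Homo sapiens) for cytotoxicity, read by XTT assay, with a stated time of 72 h; on this read-out lower numbers stand for stronger inhibition and higher numbers for weaker inhibition. Compound 1, `COc1ccc(/C=N/Nc2nc(C)c[se]2)cc1`, and compound 2, `COc1ccc(/C=N/Nc2nc(-c3ccccc3)c[se]2)cc1`, share a core and differ in one place: phenyl in place of methyl on an aromatic carbon. In this assay compound 1 reaches only the limit of the assay, > 84900 nM, and not a number. Compound 2 gives a measured value of 50900 nM. Taken together, this is an at least 1.6-fold lower number from compound 1 to compound 2 (0.22 log units; that floor lies within the scatter), so the step is a floor whose true size is not known.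

Compound 3, `Cc1c[se]c(NNC(=O)c2ccc(Cl)cc2)n1`, carries a different core; the difference between the core of compound 1 and the core of compound 3 is not broken down here. In this assay compound 3 also reaches only a limit, > 79400 nM, and not a number.

Compound 4, `O=C(NNc1nc(-c2ccccc2)c[se]1)c1ccc(Cl)cc1`, has not yet been measured. It stands to compound 3 exactly as compound 2 stands to compound 1: phenyl in place of methyl on an aromatic carbon. Both place descriptions read the same word for word, so the change is the same one made twice.

The expectation for compound 4 rests on the measured pair, where the step of an at least 1.6-fold lower number from compound 1 to compound 2 (0.22 log units; that floor lies within the scatter) is only a floor. Since compound 3 sits at a limit, an estimated step of an at least 1.4-fold lower number from compound 3 to compound 4 (0.15 log units; that floor lies within the scatter) is expected, reaching a number close to the edge of what this assay resolves. Compound 4 is therefore estimated at 55000 nM, with a range from 25000 nM to 150000 nM.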

Compound 4, half-maximal inhibitory concentration: 65100 nM
For compound 4 the middle estimate is 1.2-fold (0.07 log units) below the measured one; low and high end bracket the measured number.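

On the core of compound 3, phenyl in place of methyl on an aromatic carbon gives an at least 1.2-fold lower number from compound 3 to compound 4 (0.08 log units; that floor lies within the scatter) in this assay. Compound 3 stands at a limit of the assay, > 79400 nM, and not a number, so this step is a floor and its true size is not known. In both pairs the methyl compound stands at a limit and the phenyl compound gives a number, which fits a change that carries from one core to the other, but both floors lie within the scatter, so the pairs do not show that the change carries over with any particular size: the same change on two cores in this assay, an at least 1.6-fold lower number (0.22 log units; that floor lies within the scatter) from compound 1 to compound 2 and an at least 1.2-fold lower number (0.08 log units; that floor lies within the scatter) from compound 3 to compound 4; the limit leaves it open whether they differ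

The compounds shown leave open what other groups would do at this same place on the ring, for example an amine, a carboxylic acid or a longer chain. They also leave open how phenyl in place of methyl would behave on cores other than these two, and whether any such change would move a value clearly beyond the scatter in this assay.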